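Carbonyl substituent variation on the shared core

The source may report more compounds than this note shows. Statements on the series, on what has been measured and on what is new or still open speak of the compounds shown alone.

Measured compounds:
compound 1 `COC(=O)N1CCC(Oc2ncnc3c2CCN3c2ccc(S(C)(=O)=O)cc2F)CC1` gives 316 nM
compound 2 `CCCOC(=O)N1CCC(Oc2ncnc3c2CCN3c2ccc(S(C)(=O)=O)cc2F)CC1` gives 79.4 nM
compound 3 `CC(C)(C)COC(=O)N1CCC(Oc2ncnc3c2CCN3c2ccc(S(C)(=O)=O)cc2F)CC1` gives 39.8 nM

All three values come from a functional assay on CHO-K1 cells for agonist activity at Glucose-dependent insulinotropic receptor (Homo sapiens), read by a luciferase reporter, with a stated time of 5 h; on this read-out lower numbers stand for an effect already at smaller amounts and higher numbers for an effect only at larger amounts of compound. Compound 3 sits at the low end of the three numbers; a 2.0-fold lower number from compound 2 to compound 3 (0.30 log units; within the scatter), so compound 3 cannot be set apart from compound 2, whereas a 7.9-fold lower number from compound 1 to compound 3 (0.90 log units; beyond the scatter) and a 4.0-fold lower number from compound 1 to compound 2 (0.60 log units; beyond the scatter) both lie beyond the scatter.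

Compound 4 `CSC(=O)N1CCC(Oc2ncnc3c2CCN3c2ccc(S(C)(=O)=O)cc2F)CC1` has not been measured. Its change from compound 3 is methylsulfanyl in place of neopentyloxy on a carbonyl carbon. The measured steps bear on it only partly: both a 4.0-fold lower number from compound 1 to compound 2 (0.60 log units; beyond the scatter) and a 7.9-fold lower number from compound 1 to compound 3 (0.90 log units; beyond the scatter) show numbers falling as the group on the carbonyl oxygen grows from methyl outward, and compound 4 returns to a small group of the same size as that of compound 1. Among the measured compounds shown here, no measured step covers exchanging the carbonyl oxygen for sulfur, so that part of the change is uncovered. On the chain-size evidence alone the number is expected to rise, a 5.0-fold higher number from compound 3 to compound 4 (0.70 log units; beyond the scatter), toward the value of compound 1. The estimate for compound 4 is 200 nM, with a range of 60 nM to 700 nM.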

Compound 4, half-maximal effective concentration: 251 nM
For compound 4 the middle estimate is 1.3-fold (0.10 log units) below the measured one; measured number inside the range.
By their numbers in this assay, from the lowest: compounds 3 and 2 (each within the scatter of the next); then compounds 4 and 1 (each within the scatter of the next).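

In this assay, a 1.3-fold lower number from compound 1 to compound 4 (0.10 log units; within the scatter), so at this carbonyl carbon, with a methyl group kept, sulfur in place of oxygen gives no change that can be told from the scatter, a comparison the oxygen-linked compounds alone could not offer. The longer oxygen-linked groups stay apart from methylsulfanyl, with a 3.2-fold higher number from compound 2 to compound 4 (0.50 log units; beyond the scatter) and a 6.3-fold higher number from compound 3 to compound 4 (0.80 log units; beyond the scatter), so among these four compounds propoxy and neopentyloxy separate from the two small groups, and methylsulfanyl reads with methoxy. Nothing available here bears on the origin of these differences.

Among the compounds shown here, open is whether propylsulfanyl or neopentylsulfanyl on the carbonyl carbon would track propoxy and neopentyloxy, since the sulfur link is seen only with methyl. Also open, on these data alone, is how an amine such as dimethylamino, or a plain carbon chain, would read at this carbonyl carbon in this assay.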